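The compounds below may be only part of what the source reports. "The series", "measured", "known", "first", "only" and "open" are said of these compounds alone.

Compound 1 (`O=C(/C=C/c1ccc(OCc2ccccc2)cc1)c1ccccc1`) was tested in a functional assay on HCT-116 cells (Homo sapiens) for inhibition, read by sulforhodamine B assay, with a stated time of 3 days; on this read-out lower numbers stand for stronger inhibition of growth and higher numbers for weaker inhibition of growth. In this read-out compound 1 gives > 50000 nM, which is a limit of the assay and not a number. Compound 2 (`O=C(/C=C/c1ccccc1)c1ccc(OCc2ccccc2)cc1`) was tested in the same way. Compound 2 gives > 50000 nM, which is likewise a limit. Compound 1 thus has no number to start from, only its limit.

Compound 3 (`O=C(/C=C/c1ccc(Cl)cc1)c1ccccc1`) departs from compound 1 in one place, with chloro in place of benzyloxy on an aromatic carbon. Going by the values given here, no measured pair shows what such a change does in this assay, so only a small move towards stronger inhibition of growth is expected, not much beyond the scatter. The expected step is an at least 1.6-fold lower number from compound 1 to compound 3 (0.22 log units; that floor lies within the scatter). For compound 3 the estimated value is 30000 nM, with an expected range from 10000 nM to 80000 nM.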

Compound 3, concentration for 50% growth inhibition: 16500 nM
Compound 3: the middle estimate sits 1.8-fold (0.26 log units) above what was measured, within the range that was stated.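

The change from benzyloxy to chloro on this aromatic carbon brings an at least 3.0-fold lower number from compound 1 to compound 3 (0.48 log units; beyond the scatter), which shows that this position can influence the result in this assay. The size of that step is only a floor, because compound 1 rests on a limit of the assay and not on a number: the limit of > 50000 nM in this assay, at which 2 of the 3 values shown sit. Compound 3 also shows that a measurable number on this core does not require the benzyloxy group.

Whether the gain belongs to chloro itself or simply to the loss of benzyloxy stays open: among the compounds shown, no methoxy, fluoro or amine stands on this carbon. Nor do the compounds tell whether chloro would act in the same way at the place where compound 2 carries its benzyloxy.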